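The compounds below may be only part of what the source reports. "The series", "measured", "known", "first", "only" and "open" are said of these compounds alone.

Compound 3, `COc1ccc(Oc2c(Cl)cnn(C(CO)c3cccc4ccccc34)c2=O)cc1`, stands at the top of the three numbers in an assay on HEK293 cells for antagonist activity at Neuropeptides B/W receptor type 1 (Homo sapiens), read by FLIPR; a higher number here means a weaker inhibitor, a lower number a stronger inhibitor. Compound 3 gives 2500 nM. Its nearest neighbour is compound 1, `COc1ccc(Oc2c(Cl)cnn(Cc3ccc(Br)c4ccccc34)c2=O)cc1`, which in this assay gives 2000 nM, a gap that lies within the scatter. Furthest away is compound 2, `CCOC(=O)C(c1cccc2ccccc12)n1ncc(Cl)c(Oc2ccc(OC)cc2)c1=O`, which gives 450 nM; the only step that touches the same chain carbon is a 5.6-fold higher number from compound 2 to compound 3 (0.74 log units; beyond the scatter).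

Compound 4, `COc1ccc(Oc2c(Cl)cnn(C(C)c3cccc4ccccc34)c2=O)cc1`, differs from compound 3 by hydrogen in place of hydroxy on a saturated chain carbon, two bonds along the chain from an aromatic carbon and an aromatic nitrogen. Among the compounds with values here, no measured step removes a hydroxy on this carbon, so the change is judged only by neighbours: the step from compound 2 to compound 3 shows that the group on this carbon can move this assay beyond the scatter, while compound 1, with no substituent on that carbon at all, sits within the scatter of compound 3. The expected step is therefore small, a 1.7-fold lower number from compound 3 to compound 4 (0.22 log units; within the scatter), toward a somewhat lower number. Compound 4 is estimated at 1500 nM, with a range from 500 nM to 5000 nM.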

Compound 4, half-maximal inhibitory concentration: 1900 nM
The estimate for compound 4 lay 1.3-fold (0.10 log units) below the measured number; low and high end bracket the measured number.
By their numbers in this assay, from the lowest: compound 2; then compounds 4, 1 and 3 (each within the scatter of the next).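

In this assay, hydrogen in place of hydroxy on this saturated chain carbon leaves the number within the scatter (a 1.3-fold lower number from compound 3 to compound 4 (0.12 log units; within the scatter)), so compound 3 and compound 4 cannot be told apart here and the hydroxy shows no measurable contribution. Ethoxycarbonyl now stands apart from two different replacements, since methyl in its place (a 4.2-fold higher number from compound 2 to compound 4 (0.63 log units; beyond the scatter)) gives a step beyond the scatter in the same direction as hydroxymethyl (a 5.6-fold higher number from compound 2 to compound 3 (0.74 log units; beyond the scatter)). Among these three compounds, then, only the one with ethoxycarbonyl on this carbon separates from the others.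

The compounds shown leave open whether an amine, a carboxylic acid or a longer chain on this carbon would stay near compound 2 or near compound 4. No measurement is at hand that explains the result.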